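Working notes: from compound 3 to compound 4

The source may hold more compounds than are shown below. What is called first, only, known or untested is meant among the compounds shown, and "the series" means these compounds.

Values in a functional assay on MCF7 cells (Homo sapiens) for antiproliferative activity, read by MTT assay, with a stated time of 72 h; a lower number here means a stronger inhibitor, a higher number a weaker inhibitor:
- compound 1 `COc1ccccc1-c1cn(C[C@H](O)[C@H]2OC(=O)C(OCc3ccccc3)=C2OCc2ccccc2)nn1`: > 100000 nM, a limit
- compound 2 `O=C1O[C@H]([C@@H](O)Cn2cc(CNS(=O)(=O)c3ccc(Cl)cc3)nn2)C(OCc2ccccc2)=C1OCc1ccccc1`: 4170 nM
- compound 3 `Cc1ccc(-c2cn(C[C@H](O)[C@H]3OC(=O)C(OCc4ccccc4)=C3OCc3ccccc3)nn2)cc1`: > 100000 nM, a limit
- compound 4 `O=C1O[C@H]([C@@H](O)Cn2cc(CCO)nn2)C(OCc2ccccc2)=C1OCc1ccccc1`: not yet measured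

Compound 3 has no number, only a limit. It sits with compound 1 at the limit of > 100000 nM in this assay, at which 2 of the 3 values shown sit.

The next change puts 2-hydroxyethyl in place of 4-methylphenyl on an aromatic carbon.

Three measured steps replace the group on that carbon. Two are large: an at least 23-fold lower number from compound 1 to compound 2 (1.37 log units; beyond the scatter) and an at least 23-fold higher number from compound 2 to compound 3 (1.37 log units; beyond the scatter). The third cannot be sized: a step that the two limits leave unreadable from compound 1 to compound 3. Both large steps turn on the (((4-chlorophenyl)sulfonyl)amino)methyl group of compound 2, and 2-hydroxyethyl does not contain that group. Within the data shown here, no measured step covers 2-hydroxyethyl itself, so these steps give only a loose guide.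

Among the measured compounds shown here, with compound 2 at 4170 nM as the only number, a move towards a lower number in this assay is expected to be modest. A result at the limit remains quite possible. The expected step is an at least 2.5-fold lower number from compound 3 to compound 4 (0.39 log units; beyond the scatter). For compound 4 the estimated value is 40000 nM. The expected range for compound 4 runs from 8000 nM to 100000 nM.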

Compound 4, half-maximal inhibitory concentration: 63400 nM
Compound 4: middle estimate off by 1.6-fold (0.20 log units), on the low side; measured number inside the range.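

Compound 1 and compound 3, with 2-methoxyphenyl and 4-methylphenyl on this aromatic carbon, give only a limit and no number in this assay: the limit of > 100000 nM in this assay, at which 2 of the 4 values shown sit.

Compound 4 shows that a small open chain without a ring can give a measurable number at this position, yet the floors of the steps, an at least 1.5-fold lower number from compound 3 to compound 4 (0.19 log units; that floor lies within the scatter) and an at least 1.5-fold lower number from compound 1 to compound 4 (0.19 log units; that floor lies within the scatter), do not establish a real gain over either ring-bearing compound. Among these compounds, the step of a 15-fold higher number from compound 2 to compound 4 (1.18 log units; beyond the scatter) is the first readable comparison between two numbers at this position, and it shows that 2-hydroxyethyl does not match the (((4-chlorophenyl)sulfonyl)amino)methyl group of compound 2 in this read-out.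

Going by these compounds, it remains open whether the terminal hydroxyl of compound 4 contributes anything, since no plain ethyl group stands beside it for comparison. On these data alone, it is also open whether an amine, a carboxylic acid or a longer chain on this carbon would bring the number closer to that of compound 2, or whether the sulfonyl amino unit is needed for such a value.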